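The source may hold more compounds than are shown below. What is called first, only, known or untested is meant among the compounds shown, and "the series" means these compounds.

Measured so far, in a functional assay on V79 cells (Cricetulus griseus) for cytotoxicity, read by colony formation; on this read-out lower numbers stand for stronger inhibition and higher numbers for weaker inhibition:

compound 1, `CNCC1(C)CCN(c2c(F)cc3c(=O)c(C(=O)O)cn(C4CC4)c3c2F)C1`: 8 ug/mL
compound 2, `CNCC1(C)CCN(c2c(F)cc3c(=O)c(C(=O)O)cn(C4CC4)c3c2C(F)(F)F)C1`: 230 ug/mL
compound 3, `Cc1c(F)c(N2CCC(N)C2)c(C(F)(F)F)c2c1c(=O)c(C(=O)O)cn2C1CC1`: 290 ug/mL

Compound 2 and compound 1 share a core and differ in one place: fluoro in place of trifluoromethyl on an aromatic carbon. This change gave a 29-fold lower number from compound 2 to compound 1 (1.46 log units; beyond the scatter). Compound 3 carries a different core, and the difference between the two cores is not broken down here; its number in this assay sits near that of compound 2.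

Compound 4, `Cc1c(F)c(N2CCC(N)C2)c(F)c2c1c(=O)c(C(=O)O)cn2C1CC1`, is not yet measured. It differs from compound 3 by fluoro in place of trifluoromethyl on an aromatic carbon. This is the same kind of change as that from compound 2 to compound 1, not the same: here the place is also ortho to a 3-aminopyrrolidin-1-yl group and para to a methyl group.

On the strength of a 29-fold lower number from compound 2 to compound 1 (1.46 log units; beyond the scatter), a step of about a 24-fold lower number from compound 3 to compound 4 (1.38 log units; beyond the scatter) is expected, somewhat damped for the altered surroundings. Compound 4 is therefore estimated at 12 ug/mL, between 4 ug/mL and 40 ug/mL.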

Compound 4, half-maximal inhibitory concentration: 11 ug/mL
Compound 4: the middle estimate sits 1.1-fold (0.04 log units) above what was measured; the range from low to high includes it.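

In this assay, fluoro in place of trifluoromethyl on an aromatic carbon gave a 26-fold lower number from compound 3 to compound 4 (1.42 log units; beyond the scatter), so the step carried over to the second core at much the same size: the same change on two cores in this assay, a 29-fold lower number (1.46 log units; beyond the scatter) from compound 2 to compound 1 and a 26-fold lower number (1.42 log units; beyond the scatter) from compound 3 to compound 4, 1.1-fold (0.04 log units) apart, within the scatter of two such steps

This rests on two pairs on two cores, read in one assay, and does not show that the step would keep its size on any further core. Nor can the two pairs tell which feature of the exchange accounts for the step, since only these two groups are compared at this place.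

Open, on these data alone, is where a chloro, methoxy or nitrile group at the same aromatic carbon would fall relative to the fluoro and trifluoromethyl pairs on each core.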